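The compounds below may be only part of what the source reports. "The series", "measured", "known", "first", "only" and "open" are said of these compounds alone.

Measured in a functional assay on A2780 cells (Homo sapiens) for inhibition, read by sulforhodamine B assay, with a stated time of 96 h; a lower number here means a stronger inhibitor of growth, a higher number a weaker inhibitor of growth:
- Compound 1 `CC[C@@H](Nc1nc(NCc2ccccn2)c2ncn(C(C)C)c2n1)C(C)(C)O`: 34000 nM
- Compound 2 `CCC(O)[C@@H](CC)Nc1nc(NCc2ccccn2)c2ncn(C(C)C)c2n1`: 22000 nM

In this assay compound 2 gives 22000 nM, within the scatter of compound 1 at 34000 nM. Compound 3 `CC[C@@H](Nc1nc(NCc2ccccn2)c2ncn(C(C)C)c2n1)C(O)C(C)(C)C` differs from compound 2 by tert-butyl in place of ethyl on a saturated chain carbon bound to an oxygen on a saturated carbon and a saturated chain carbon, turning 1-hydroxypropyl into 1-hydroxy-2,2-dimethylpropyl. Among the measured compounds shown here, the only measured step that bears on this, a 1.5-fold lower number from compound 1 to compound 2 (0.19 log units; within the scatter), changes the same side chain. No tert-butyl group has been measured, so that step is a limited guide, and no change beyond the scatter is expected in this assay. The estimated change is a 1.1-fold lower number from compound 2 to compound 3 (0.04 log units; within the scatter). For compound 3 the expected value is 20000 nM, with an estimated range of 9000 nM to 50000 nM.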

Compound 3, concentration for 50% growth inhibition: 23000 nM
Compound 3: middle estimate off by 1.2-fold (0.06 log units), on the low side; the range from low to high includes it.
By their numbers in this assay, from the lowest: compounds 2, 3 and 1 (each within the scatter of the next).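

In this assay, tert-butyl in place of ethyl on a saturated chain carbon bound to an oxygen on a saturated carbon and a saturated chain carbon gives a 1.0-fold higher number from compound 2 to compound 3 (0.02 log units; within the scatter), so the larger group brings no change beyond the scatter at this position. The 1-hydroxy-2,2-dimethylpropyl group in place of 1-hydroxy-1-methylethyl gives a 1.5-fold lower number from compound 1 to compound 3 (0.17 log units; within the scatter), which places all three side chains within the scatter of one another. On these data alone, all three side chains keep their hydroxyl, so it remains open whether an amine or a carboxylic acid there would shift the number beyond the scatter. No evidence bearing on these results is at hand.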